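From 2-Chlorobenzyl to 4-Fluorobenzyl in a Shared Core

The source may report more compounds than this note shows. Statements on the series, on what has been measured and on what is new or still open speak of the compounds shown alone.

Of the compounds shown here, three sharing one core have been tested in a functional assay on the whole organism (artery, strain albino) with Rattus norvegicus as the target, with a stated time of 720 min, at a dose of 10 mg/kg by the oral route; a higher number here means more inhibition at the dose given (going by the name of the read-out), a lower number less inhibition: compound 1 `CC1=C(C(=O)Nc2ccc(F)cc2)C(c2ccc([N+](=O)[O-])cc2)N=C(SCc2ccccc2Cl)N1`, compound 2 `CC1=C(C(=O)Nc2ccc([N+](=O)[O-])cc2)C(c2ccc(Br)cc2)N=C(SCc2ccccc2Cl)N1` and compound 3 `CC1=C(C(=O)Nc2ccc([N+](=O)[O-])cc2)C(c2cccc([N+](=O)[O-])c2)N=C(SCc2ccccc2Cl)N1`. In this assay compound 1 gives 13.9%, compound 2 gives 6.7% and compound 3 gives 11.3%. The number for compound 3 sits between those of compound 1 and compound 2, and all three lie within the usual scatter of one another, so no ranking among them can be claimed. Among the compounds with values here, the only single-point step measured, a number 4.6 percentage points higher from compound 2 to compound 3 (within the scatter), concerns the aryl group on the saturated ring carbon and stays within the scatter.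

Compound 4 `CC1=C(C(=O)Nc2ccc([N+](=O)[O-])cc2)C(c2cccc([N+](=O)[O-])c2)N=C(SCc2ccc(F)cc2)N1` differs from compound 3 in one place: 4-fluorophenyl in place of 2-chlorophenyl on a saturated chain carbon bound to a sulfur. Within the data shown here, no measured step touches the benzyl group on the sulfur, so nothing in these data points to a shift at that position. Compound 4 is therefore expected to give 11% in this assay, with a range from 2% to 22%. The expected step is a number 0.3 percentage points lower from compound 3 to compound 4 (within the scatter), which would stay within the scatter.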

Compound 4, a percentage reported as inhibition, in the whole organism at one dose (the size of the read-out at that dose, not a potency): 20.1%
Compound 4: middle estimate off by 9.1 percentage points, on the low side; the range from low to high includes it.
By their numbers in this assay, from the lowest: compounds 2, 3, 1 and 4 (each within the scatter of the next, the first and the last beyond it).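

Within the data shown here, all three earlier compounds carry 2-chlorobenzyl on the sulfur, so compound 4 gives the first reading of any change at this position. In this assay, the change to 4-fluorobenzyl gives a number 8.8 percentage points higher from compound 3 to compound 4 (within the scatter), so these two compounds do not separate the two benzyl groups, although a real difference cannot be excluded from this single pair. No measurement at hand bears on this step.

On these data alone, the change moves from 2-chloro to 4-fluoro in one go, so the halogen and its ring position cannot be told apart, and it is open whether the same change would read alike with the aryl and amide groups of compound 1 or compound 2. Also open, as far as these compounds go, is how an unsubstituted benzyl, a phenethyl chain or a simple methyl on the sulfur would read in this assay.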